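This account rests on a few compounds, and the source may have more. Where it says the series, first, only, none or still open, it means among the compounds named here.

Measured in an ADME assay on CCRF-HSB-2 cells (Homo sapiens) for cytotoxicity, with a stated time of 7 days; a lower number here means that less compound is tolerated, a higher number that more compound is tolerated:
compound 1 `CCCCSc1nc(N)nc2c1ncn2/C=C1/CC1(CO)CO` — compound 1 gives 89000 nM.
compound 2 `CC(C)CNc1nc(N)nc2c1ncn2/C=C1/CC1(CO)CO` — compound 2 returns only a limit, > 20000 nM.
compound 3 `CCCSc1nc(N)nc2c1ncn2/C=C1/CC1(CO)CO` — compound 3 gives 98000 nM.

Compound 3 holds the highest of the two numbers in this assay; compound 1 is nearest, a 1.1-fold higher number from compound 1 to compound 3 (0.04 log units; within the scatter), so shortening the sulfanyl chain by one methyl leaves the number unchanged. Compound 4 `Nc1nc(NC2CCCC2)c2ncn(/C=C3/CC3(CO)CO)c2n1` differs from compound 3 in cyclopentylamino in place of propylsulfanyl on an aromatic carbon. Among the measured compounds shown here, the two steps that exchange a sulfanyl chain for an amino group, a step that the limit leaves unreadable from compound 1 to compound 2 and a step that the limit leaves unreadable from compound 2 to compound 3, are unreadable because of the limit of > 20000 nM in this assay, at which 1 of the 3 values shown sits, so no measured step gives the size of an amino-for-sulfanyl swap. Compound 4 may likewise return only a limit. Compound 4 is estimated at 60000 nM (20000 nM to 180000 nM). The expected step is a 1.6-fold lower number from compound 3 to compound 4 (0.21 log units; within the scatter).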

Compound 4, half-maximal cytotoxic concentration: > 20000 nM
Compound 4 was reported as a limit; the forecaster's own chance of this, stated with the estimate: 40%; the middle value lies beyond the limit too.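

Compound 4 also returns only a limit in this assay, so no step from compound 1, compound 2 or compound 3 to compound 4 can be read: the limit of > 20000 nM in this assay, at which 2 of the 4 values shown sit.

The compounds shown leave open how large the exchange of a sulfanyl chain for an amino group is, and how compound 2 and compound 4 compare.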